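Replacing a cyclopropyl with an aryl amide at the amine

A few compounds are considered here, and "the series" means these few. Any claim that something is new, unique, unknown or untested is made for them only; others in the source may bear on it.

Compound 1, `CNc1nc(-c2ccccc2)nc2c1nnn2Cc1ccccc1Cl`: in an assay on isolated protein for binding affinity to adenosine receptor A1 (Bos taurus) (a higher number here means a weaker inhibitor, a lower number a stronger inhibitor), compound 1 gives 191000000 nM.
Compound 2, `Fc1ccccc1Cn1nnc2c(NC3CC3)nc(-c3ccccc3)nc21`: compound 2 gives 15000000 nM.
Compound 3, `Clc1ccccc1Cn1nnc2c(NC3CC3)nc(-c3ccccc3)nc21`: compound 3 gives 11000000 nM.

Among these three, compound 2 has the second highest number. Its nearest neighbour is compound 3, and the step of a 1.4-fold lower number from compound 2 to compound 3 (0.13 log units; within the scatter) lies within the scatter, so the two cannot be told apart. Compound 1 sits far higher than both, as its value shows.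

Compound 4, `COc1ccc(C(=O)Nc2nc(-c3ccccc3)nc3c2nnn3Cc2ccccc2F)cc1`, differs from compound 2 in one place: (4-methoxyphenyl)carbonyl in place of cyclopropyl on a nitrogen on an aromatic ring. For the measured compounds named here, no measured step changes this group in the same way. Going by the values given here, the only step at the same nitrogen is a 17-fold lower number from compound 1 to compound 3 (1.24 log units; beyond the scatter), a large move to a lower number when cyclopropyl replaced methyl. The step of a 1.4-fold lower number from compound 2 to compound 3 (0.13 log units; within the scatter) touches a different part of the molecule and only shows that compound 2 and compound 3 serve equally as a starting point. Among the compounds with values here, because the one change seen at this nitrogen gave a 17-fold lower number from compound 1 to compound 3 (1.24 log units; beyond the scatter), a lower number is expected for compound 4 as well, but the new group is of a different kind, so the expectation is loose. Compound 4 is estimated at 5000000 nM, with a range from 500000 nM to 50000000 nM. That estimate corresponds to an expected step of a 3.0-fold lower number from compound 2 to compound 4 (0.48 log units; beyond the scatter).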

Compound 4, inhibition constant: 21900000 nM
Estimate against measurement, compound 4: 4.4-fold (0.64 log units) below; the range from low to high includes it.
By their numbers in this assay, from the lowest: compounds 3, 2 and 4 (each within the scatter of the next); then compound 1.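

In this assay, putting (4-methoxyphenyl)carbonyl, with 10 heavy atoms and an aromatic ring, in place of cyclopropyl, with 3 heavy atoms, gives a 1.5-fold higher number from compound 2 to compound 4 (0.16 log units; within the scatter), so the two compounds cannot be told apart. For the compounds shown here, this nitrogen had so far been seen only in a large move, a 17-fold lower number from compound 1 to compound 3 (1.24 log units; beyond the scatter), where cyclopropyl replaced methyl, so the substituent here can matter, yet this much larger group of a different kind leaves the number indistinguishable from that of the cyclopropyl compound. Nothing at hand explains why one change at this nitrogen registers clearly and the other does not.

The compounds shown leave open whether the carbonyl or the 4-methoxyphenyl part carries the result, which a simple acetyl group or a plain benzoyl group on the same nitrogen would help to separate. They also leave open whether a chloro in place of the fluoro would stay within the scatter on this amide as it does on the cyclopropyl compounds, and whether a hydroxyl or a dimethylamino group in place of the methoxy would shift the number.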